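This account rests on a few compounds, and the source may have more. Where it says the series, first, only, none or still open, it means among the compounds named here.

In a physicochemical assay for lipophilicity, using the shake flask method, in phosphate buffer, measured as octanol-water partition, with a stated time of 30 min, at pH 7.4 (on this read-out higher numbers stand for higher lipophilicity and lower numbers for lower lipophilicity), compound 3 `CN(C)C(=O)c1cc(-c2cnc(NCc3c(F)ccc4c3CCO4)c3cn[nH]c(=O)c23)n(C)n1` gives 2.1. Compound 1 `Cc1nc(CO)ccc1-c1cnc(NCc2c(F)ccc3c2CCO3)c2cn[nH]c(=O)c12` gives 2.4, within the scatter of that number, and compound 2 `CC(=O)N1CCC(c2cnc(NCc3c(F)ccc4c3CCO4)c3cn[nH]c(=O)c23)CC1` gives 2.9. Compound 4 `Cc1nc(CN(C)C)ccc1-c1cnc(NCc2c(F)ccc3c2CCO3)c2cn[nH]c(=O)c12` has not been measured. Its structural change is 6-((dimethylamino)methyl)-2-methylpyridin-3-yl in place of 3-(dimethylcarbamoyl)-1-methyl-1H-pyrazol-5-yl on an aromatic carbon, with 6-((dimethylamino)methyl)-2-methylpyridin-3-yl entering on an aromatic carbon. The closest guide is a number 0.30 log units lower from compound 1 to compound 3 (within the scatter), as compound 1 carries 6-(hydroxymethyl)-2-methylpyridin-3-yl at this place. A second guide, a number 0.80 log units lower from compound 2 to compound 3 (beyond the scatter), shows a larger step for another swap at the same place. Among the compounds with values here, no measured pair isolates the exchange of hydroxymethyl for dimethylaminomethyl, so the expected move is a small rise, a number 0.40 log units higher from compound 3 to compound 4 (beyond the scatter). Compound 4 is estimated at 2.5, with an expected range from 2 to 3.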

Compound 4, distribution coefficient: 2
For compound 4 the middle estimate is 0.50 log units above the measured one; low and high end bracket the measured number.
By their numbers in this assay, from the lowest: compounds 4, 3 and 1 (each within the scatter of the next, the first and the last beyond it); then compound 2.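

In this assay, compound 1 and compound 4 differ only on a saturated chain carbon bound to an aromatic carbon, so the exchange of hydroxy for dimethylamino can now be read directly (a number 0.40 log units lower from compound 1 to compound 4 (beyond the scatter)). On the aromatic carbon of the core, 6-((dimethylamino)methyl)-2-methylpyridin-3-yl cannot be told apart from 3-(dimethylcarbamoyl)-1-methyl-1H-pyrazol-5-yl (a number 0.10 log units lower from compound 3 to compound 4 (within the scatter)), but it stands clearly apart from 1-acetylpiperidin-4-yl (a number 0.90 log units lower from compound 2 to compound 4 (beyond the scatter)). Nothing measured here gives a reason for these steps.

From the compounds shown here alone, whether a primary amine or a carboxylic acid on that chain carbon would fall near compound 1 or compound 4 remains open.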